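Furanyl pendant replacing methoxycarbonylphenyl in the tricyclic series

The compounds below may be only part of what the source reports. "The series", "measured", "known", "first", "only" and "open" are said of these compounds alone.

Compound 1 `CCc1ccccc1-n1nc(C)c2c1NC(=O)[C@H](C)S[C@@H]2c1ccc(Oc2ccccc2)cc1` gives 1100 nM in an assay on isolated protein for agonist activity at Bile acid receptor (Homo sapiens), read by AlphaScreen, with a stated time of 30 min; a lower number here means that less compound is needed, a higher number that more compound is needed for the effect. Compound 3 `COc1ccc(C2SC(C)C(=O)Nc3c2c(C)nn3-c2ccccc2C)c(OC)c1` gives 10500 nM in this assay. Compound 2 `COC(=O)c1ccc(-c2ccc([C@H]3S[C@@H](C)C(=O)Nc4c3c(C)nn4-c3ccccc3C)cc2)cc1` is reported as "not active" (no number reported) in this assay, so no single number stands for it and the step to compound 4 has no measured starting value. Compound 4 `Cc1ccccc1-n1nc(C)c2c1NC(=O)[C@H](C)S[C@@H]2c1ccc(-c2ccco2)cc1` differs from compound 2 by furan-2-yl in place of 4-(methoxycarbonyl)phenyl on an aromatic carbon. Going by the values given here, no step between measured compounds is available for this change; the only guide is that other pendants on the same six-membered ring of carbon only give measurable values, compound 1 at 1100 nM and compound 3 at 10500 nM. Compound 4 is therefore expected to move from inactivity into the measurable range, with an estimate of 3000 nM in this assay and a range of 800 nM to 15000 nM. A report of no activity, as seen for compound 2, remains a real possibility.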

Compound 4, half-maximal effective concentration: 3600 nM
Estimate against measurement, compound 4: 1.2-fold (0.08 log units) below; the range from low to high includes it.
By their numbers in this assay, from the lowest: compound 1; then compound 4; then compound 3.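

Compound 2 carries no number in this assay, and its change to compound 4 gives no readable step. The compounds shown leave open how furan-2-yl compares with other pendants on an otherwise identical core. No evidence bears on the result.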